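Recasting the Indole Amide of Compound 2

This account rests on a few compounds, and the source may have more. Where it says the series, first, only, none or still open, it means among the compounds named here.

Three compounds have been measured in an assay on isolated protein (thoracic aorta, strain Sprague-Dawley) for antagonist activity at Alpha-1D adrenergic receptor (Rattus norvegicus), with a stated time of 20 min; a lower number here means tighter binding, a higher number weaker binding:
compound 1, `COc1ccc2[nH]c(C(=O)NCCCN3CCN(c4ccccc4OC)CC3)cc2c1`, 58.9 nM
compound 2, `COc1ccccc1N1CCN(CCCNC(=O)c2cc3cc(O)ccc3[nH]2)CC1`, 26.9 nM
compound 3, `COc1ccccc1N1CCN(CCCNC(=O)c2cc3cccc([N+](=O)[O-])c3[nH]2)CC1`, 28.2 nM

Compound 2 has the lowest number of the three; compound 3 lies within the scatter of it, while compound 1 lies beyond. Going by the values given here, the only single-point step, a 2.2-fold lower number from compound 1 to compound 2 (0.34 log units; beyond the scatter), is modest. Compound 4, `COc1ccccc1N1CCN(CCCNC(=O)c2cn(C)c3ccccc23)CC1`, differs from compound 2 by 1-methyl-1H-indol-3-yl in place of 5-hydroxy-1H-indol-2-yl on a carbonyl carbon. Among the compounds with values here, no measured step covers this change; the step from compound 1 to compound 2 only shows that altering the oxygen on that ring matters modestly. Compound 4 lacks that hydroxyl altogether and carries a methyl on the ring nitrogen, so a somewhat higher number is expected for compound 4 in this assay, a step of a 2.4-fold higher number from compound 2 to compound 4 (0.38 log units; beyond the scatter). The estimate for compound 4 is 65 nM, with a range from 20 nM to 220 nM.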

Compound 4, dissociation constant: 5.5 nM
Compound 4: the middle estimate sits 12-fold (1.07 log units) above what was measured, outside the stated range (below it).
By their numbers in this assay, from the lowest: compound 4; then compounds 2 and 3 (each within the scatter of the next); then compound 1.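

In this assay, going by these compounds alone, the group on a carbonyl carbon whose other neighbour is the amide-type nitrogen proves able to change far more than its oxygen: 1-methyl-1H-indol-3-yl in place of 5-hydroxy-1H-indol-2-yl gives the lowest number so far (a 4.9-fold lower number from compound 2 to compound 4 (0.69 log units; beyond the scatter)). A low number therefore does not depend on the hydroxyl, since the entering group has 0 hydrogen-bond donors. Nothing available accounts for this step. Several features change together, so their separate shares remain open. So does the outcome with 1H-indol-3-yl, lacking the methyl, or with an ethyl on that ring nitrogen.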